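The source may hold more compounds than are shown below. What is called first, only, known or untested is meant among the compounds shown, and "the series" means these compounds.

Compound 1 `NC(C(=O)NCC(=O)Nc1ccc(Cl)cc1C(=O)c1ccccc1)c1ccccc1` carries an amide chain on the shared core. In a functional assay on the whole organism with Mus musculus as the target, in the rotarod test (a higher number here means that more compound is needed for the effect, a lower number that less compound is needed), compound 1 gives only a limit, > 100 mg/kg, so no number is known for it. The other two compounds differ from it in several places at once. Compound 2 `CN(C)CC(=O)NCC(=O)N(C)c1ccc(Cl)cc1C(=O)c1ccccc1Cl` gives 26 mg/kg in this assay, and compound 3 `CCCCCC(=O)NCC(=O)N(C)c1ccc(Cl)cc1C(=O)c1ccccc1Cl` gives 90 mg/kg. Going by the values given here, the one measured step between neighbours, a 3.5-fold higher number from compound 2 to compound 3 (0.54 log units; beyond the scatter), concerns another part of the chain and does not mirror the change studied here. Compound 4 `CC(=O)NCC(=O)Nc1ccc(Cl)cc1C(=O)c1ccccc1` differs from compound 1 by methyl in place of amino(phenyl)methyl on a carbonyl carbon. Among the compounds with values here, no measured step covers this change, and compound 1 itself sits at the limit of > 100 mg/kg in this assay, at which 1 of the 3 values shown sits. Compound 4 is therefore expected to stay near that limit, with the step that the limit leaves unreadable from compound 1 to compound 4 expected to be small. The estimate for compound 4 is 150 mg/kg, between 60 mg/kg and 400 mg/kg.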

Compound 4, dose for half-maximal effect: > 100 mg/kg
Compound 4 ended at the assay's limit; the forecaster's own chance of this, stated with the estimate: 60%; the middle value lies beyond the limit too.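

Compound 1 and compound 4 both end at a limit rather than a number in this assay, so the step between them cannot be read: the limit of > 100 mg/kg in this assay, at which 2 of the 4 values shown sit.

As far as these compounds go, what methyl in place of amino(phenyl)methyl does to the dose needed in this assay stays open.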